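A few compounds are considered here, and "the series" means these few. Any claim that something is new, unique, unknown or untested is made for them only; others in the source may bear on it.

The measured compounds and their results:

compound 1 `COc1ccc2[nH]c(C(=O)N3CC(=O)N(Cc4ccccc4)[C@@H](CN4CCC(C)CC4)C3)cc2c1` — 0.267 h
compound 2 `COc1cccc(CN2C(=O)CN(C(=O)c3cc4cc(OC)ccc4[nH]3)C[C@@H]2CCc2ccccc2)c1` — 0.12 h
compound 3 `COc1ccc2[nH]c(C(=O)N3CC(=O)N(Cc4ccccc4)[C@@H](CN4CCN(c5ccc(F)cc5)CC4)C3)cc2c1` — 0.457 h

Three compounds sharing one core have been run in an ADME assay on microsomes from liver (Homo sapiens) for metabolic stability, with a stated time of 30 min, tested at 1 uM; a higher number here means that the compound lasts longer, a lower number that the compound disappears faster. Compound 1 gives 0.267 h in this assay, the second highest of the three numbers. Its nearest neighbour is compound 3, whose 0.457 h is a higher number but lies within the scatter of the measurement, so the two cannot be told apart. The furthest is compound 2, whose 0.12 h is a lower number and lies beyond the scatter. No pair among these three differs in a single place, so no single step can be read from them.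

Compound 4 `COc1ccc2[nH]c(C(=O)N3CC(=O)N(Cc4ccccc4)[C@@H](CN4CCCc5ccccc54)C3)cc2c1` is the next compound, not yet measured. It differs from compound 1 in one place: 1,2,3,4-tetrahydroquinolin-1-yl in place of 4-methylpiperidin-1-yl on a saturated chain carbon bound to a saturated ring carbon. The change swaps one ring for a larger fused pair of rings on the same saturated chain carbon. Among the measured compounds shown here, nothing among the measured compounds shows what such a change does in this assay. The step from compound 1 to compound 4 is expected to be small, most likely a modest move to a lower number, a 1.3-fold lower number from compound 1 to compound 4 (0.13 log units; within the scatter), and it may well stay within the scatter. Compound 4 is therefore estimated at 0.2 h, with a likely range from 0.1 h to 0.4 h.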

Compound 4, half-life: 0.183 h
The estimate for compound 4 lay 1.1-fold (0.04 log units) above the measured number, within the range that was stated.
By their numbers in this assay, from the lowest: compounds 2, 4, 1 and 3 (each within the scatter of the next, the first and the last beyond it).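

Among the compounds shown here, this is the first step at this position that can be read on its own. In this assay the exchange of 4-methylpiperidin-1-yl for 1,2,3,4-tetrahydroquinolin-1-yl on a saturated chain carbon bound to a saturated ring carbon gives a 1.5-fold lower number from compound 1 to compound 4 (0.16 log units; within the scatter) and so cannot be told apart from no change at all. The added six-membered aromatic ring of carbon only, which takes the group from 7 to 10 heavy atoms, therefore leaves the half-life of this pair within the usual scatter, and nothing in the data shown gives a reason for the small difference.

This single pair leaves open whether any group on this saturated chain carbon can move the half-life beyond the scatter, for example morpholin-4-yl, an open-chain dimethylamino group or a simple piperidin-1-yl without the methyl. It also leaves open whether the same exchange would behave alike with a group other than benzyl on the shared core, since the step has been read only once.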